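The source may report more compounds than this note shows. Statements on the series, on what has been measured and on what is new or still open speak of the compounds shown alone.

Compound 1 (`CC1=CC(C)(C)N(Cc2cn(Cc3cc4cc(C)ccc4nc3Cl)nn2)c2ccccc21`) gives 30600 nM in a functional assay on MCF7 cells (Homo sapiens) for cytotoxicity, read by MTT assay, with a stated time of 48 h; a higher number here means a weaker inhibitor, a lower number a stronger inhibitor; compound 2 (`COc1ccc2nc(Cl)c(Cn3cc(CN4c5ccccc5C(C)=CC4(C)C)nn3)cc2c1`) gives 38700 nM; compound 3 (`CC1=CC(C)(C)N(Cc2cn(Cc3cc4ccccc4nc3Cl)nn2)c2ccccc21`) gives 16200 nM.

Compound 4 (`COc1ccc2nc(Cl)c(Cn3cc(CN4c5ccc(C)cc5C(C)=CC4(C)C)nn3)cc2c1`) has not yet been measured. It differs from compound 2 by methyl in place of hydrogen on an aromatic carbon. The same change, made as methyl in place of hydrogen on an aromatic carbon, gave a 1.9-fold higher number from compound 3 to compound 1 (0.28 log units; within the scatter). The cores of compound 2 and compound 3 differ by methoxy in place of hydrogen on an aromatic carbon, and in this assay this shows as a 2.4-fold lower number from compound 2 to compound 3 (0.38 log units; beyond the scatter). Because the earlier step was a 1.9-fold higher number from compound 3 to compound 1 (0.28 log units; within the scatter), a step of similar size is expected from compound 2 to compound 4, namely a 1.5-fold higher number from compound 2 to compound 4 (0.18 log units; within the scatter). Compound 4 is therefore estimated at 58000 nM in this assay, with a likely range from 28000 nM to 120000 nM.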

Compound 4, half-maximal inhibitory concentration: 14300 nM
The estimate for compound 4 lay 4.1-fold (0.61 log units) above the measured number; the measured number lies below the stated range.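

In this assay, methyl in place of hydrogen on an aromatic carbon gave a 2.7-fold lower number from compound 2 to compound 4 (0.43 log units; beyond the scatter). The change therefore did not carry over from one core to the other with the same direction or size: the same change on two cores in this assay, a 1.9-fold higher number (0.28 log units; within the scatter) from compound 3 to compound 1 and a 2.7-fold lower number (0.43 log units; beyond the scatter) from compound 2 to compound 4, 5.1-fold (0.71 log units) apart, beyond the scatter of two such steps. This shows that, in this series, the step seen on one core cannot be assumed on another, but with a single pair on each core it does not show why the two steps part or how the change would behave on any further core.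

The compounds shown leave open how this assay would read with an amine or a carboxylic acid on that aromatic carbon. They also leave open whether a longer chain, such as ethyl, would follow methyl.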